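From 3-bromobenzyl to 4-(trifluoromethyl)benzyl

The source may hold more compounds than are shown below. What is called first, only, known or untested is meant among the compounds shown, and "the series" means these compounds.

Compound 1 (`COc1cc(OC)c(-c2coc3cc(OCc4ccc(Br)cc4)ccc3c2=O)cc1OC`) gives > 10000 nM
Compound 2 (`COc1cc(OC)c(-c2coc3cc(OCc4cccc(Br)c4)ccc3c2=O)cc1OC`) gives > 10000 nM

Both entries come from a functional assay on HUVEC cells (Homo sapiens) for antiproliferative activity, read by MTT assay, with a stated time of 24 h (on this read-out higher numbers stand for weaker inhibition and lower numbers for stronger inhibition), and both are limits of the assay, not numbers. The whole picture so far is the limit of > 10000 nM in this assay, at which 2 of the 2 values shown sit, and nothing finer. Compound 3 (`COc1cc(OC)c(-c2coc3cc(OCc4ccc(C(F)(F)F)cc4)ccc3c2=O)cc1OC`) keeps the shared core and changes one group, with 4-(trifluoromethyl)phenyl in place of 3-bromophenyl on a saturated chain carbon bound to an oxygen on an aromatic ring. Among the compounds with values here, the only measured step that bears on this is a step that the two limits leave unreadable from compound 1 to compound 2 and it offers no size to carry over. Compound 2 stands at > 10000 nM as a limit, and on that ground no clear move is expected in this assay for the new group. The expected step is a step that the limit leaves unreadable from compound 2 to compound 3 and it is only an estimate. For compound 3 the estimated value is 15000 nM with 5000 nM to 50000 nM as the expected range. The most likely report is another limit rather than a number.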

Compound 3, half-maximal inhibitory concentration: > 10000 nM
Compound 3 ended at the assay's limit (the forecaster's own chance of this, stated with the estimate: 80%); the middle value is on the limit's open side.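

No step among compound 1, compound 2 and compound 3 can be read in this assay, because each result is a limit and not a number: the limit of > 10000 nM in this assay, at which 3 of the 3 values shown sit.

The compounds shown leave open how far each one lies beyond that limit, and whether any group in this place on the shared core would give a measurable value.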